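The source may hold more compounds than are shown below. What is called first, only, known or untested is meant among the compounds shown, and "the series" means these compounds.

Compound 1, `O[C@@H](c1ccccc1)[C@H]1CO[C@H](c2ccccc2)[C@@H](C/C=C/c2ccncc2)C1`: > 100000 nM
Compound 2, `O[C@@H](c1ccccc1)[C@H]1CO[C@H](c2ccccc2)[C@@H](C/C=C/c2ccccc2F)C1`: 9530 nM

In a functional assay on HL-60 cells (Homo sapiens) for cytotoxicity, read by WST assay, with a stated time of 48 h (on this read-out lower numbers stand for stronger inhibition and higher numbers for weaker inhibition), compound 1 gives only a limit, > 100000 nM, so no number is known for it, as the limit of > 100000 nM in this assay, at which 1 of the 2 values shown sits, shows. Compound 2, in this assay, gives 9530 nM. Within the data shown here, the single measured step, an at least 10-fold lower number from compound 1 to compound 2 (1.02 log units; beyond the scatter), puts 2-fluorophenyl in place of pyridin-4-yl on a double-bonded chain carbon bound to a double-bonded chain carbon.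

Compound 3, `O[C@@H](c1ccccc1)[C@H]1CO[C@H](c2ccccc2)[C@@H](C/C=C/C2CCCC2)C1`, has not yet been measured in this assay. It differs from compound 1 by cyclopentyl in place of pyridin-4-yl on a double-bonded chain carbon bound to a double-bonded chain carbon. The change occupies the same place as the measured step to compound 2, and in both cases pyridin-4-yl leaves; only the entering group differs, cyclopentyl here rather than 2-fluorophenyl. The step from compound 1 to compound 2 was large and beyond the scatter, so a similarly large move toward a lower number is expected for compound 3, while the size of the step from compound 1 remains bounded by its limit. Compound 3 is therefore expected to give about 15000 nM, within a range from 3000 nM to 100000 nM. an at least 6.6-fold lower number from compound 1 to compound 3 (0.82 log units; beyond the scatter) is the expected step.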

Compound 3, half-maximal inhibitory concentration: 9060 nM
The estimate for compound 3 lay 1.7-fold (0.22 log units) above the measured number; the measured number falls inside the stated range.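

Within this assay, replacing pyridin-4-yl with cyclopentyl gives an at least 11-fold lower number from compound 1 to compound 3 (1.04 log units; beyond the scatter), so at this place, on a double-bonded chain carbon bound to a double-bonded chain carbon, the lower number seen with 2-fluorophenyl does not require an aromatic entering ring. The two entering groups are not separated by this read-out: the comparison gives a 1.1-fold lower number from compound 2 to compound 3 (0.02 log units; within the scatter), which leaves a fluorinated aromatic ring and a five-membered carbon ring level at this place. Of the three groups, only pyridin-4-yl carries a nitrogen, and the size of both changes from it stays a bound rather than a number because compound 1 gives only a limit: the limit of > 100000 nM in this assay, at which 1 of the 3 values shown sits.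

The compounds shown do not tell whether the ring nitrogen of pyridin-4-yl is what separates compound 1 from the others, a question that a plain phenyl or a pyridin-3-yl at this place would address. They also leave open how an amine, a carboxylic acid or a longer open carbon chain would read at this place, and whether any entering group can bring the number clearly lower than those of compound 2 and compound 3.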